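A few compounds are considered here, and "the series" means these few. Any claim that something is new, unique, unknown or untested is made for them only; others in the source may bear on it.

Compound 2 `ClCc1ccc(-c2ccc(Cn3ccnc3)cc2)cn1` gives 24% in an assay for inhibition of steroid 17-alpha-hydroxylase/17,20 lyase (Homo sapiens), using NADPH, tested at 2 uM (on this read-out higher numbers stand for a stronger effect at the one concentration tested and lower numbers for a weaker effect), the higher of the two numbers in hand; compound 1 `Fc1ccc(-c2ccc(Cn3ccnc3)cc2)cn1` gives 13%. Going by the values given here, the only measured step, a number 11 percentage points higher from compound 1 to compound 2 (beyond the scatter), is the one bearing on the position now varied. Compound 3 `c1cncc(-c2ccc(Cn3ccnc3)cc2)c1` differs from compound 2 by hydrogen in place of chloromethyl on an aromatic carbon. Removing the chloromethyl is expected to undo that modest gain, so the number for compound 3 is estimated to move a number 12 percentage points lower from compound 2 to compound 3 (beyond the scatter), ending near compound 1 or somewhat lower. Compound 3 is thus expected at 12%, within 2% to 25%.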

Compound 3, a percentage reported as inhibition, at one concentration (the size of the read-out at that concentration, not a potency): 14%
Estimate against measurement, compound 3: 2 percentage points below, and the stated range covers the measured number.
By their numbers in this assay, from the lowest: compounds 1, 3 and 2 (each within the scatter of the next, the first and the last beyond it).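

With hydrogen at this place, the reference for both substituents is now available in this assay: removing chloromethyl gives a number 10 percentage points lower from compound 2 to compound 3 (within the scatter), and replacing fluoro gives a number 1 percentage points higher from compound 1 to compound 3 (within the scatter). Neither chloromethyl nor fluoro therefore separates from hydrogen, and only the chloromethyl-fluoro pair remains apart beyond the scatter. No measurement here offers an explanation for these numbers.

From the compounds shown here alone, whether an amine, a carboxylic acid or a longer chain at this place would separate from hydrogen remains open.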